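The compounds below may be only part of what the source reports. "The series", "measured", "known", "first", "only" and "open" are said of these compounds alone.

The series shares one core. Compound 1 `Cc1ccc2c(=O)c(CSC(=S)N3CCCCC3)coc2c1` carries piperidin-1-yl on the thiocarbonyl carbon. In a functional assay on SW480 cells (Homo sapiens) for antiproliferative activity, read by MTT assay, with a stated time of 72 h (on this read-out lower numbers stand for stronger inhibition and higher numbers for weaker inhibition), compound 1 gives > 25000 nM, which is a limit of the assay and not a number. Compound 2 `Cc1ccc2c(=O)c(CSC(=S)N(C(C)C)C(C)C)coc2c1` carries diisopropylamino at the same place. In this assay compound 2 gives > 25000 nM, again a limit. Compound 3 `Cc1ccc2c(=O)c(CSC(=S)N3CCOCC3)coc2c1` carries morpholin-4-yl there. In this assay, for the measured compounds named here, compound 3 gives 3800 nM, the only numbered value to date. Compound 2 stands at the limit of > 25000 nM in this assay, at which 2 of the 3 values shown sit, and the step from compound 1 to compound 2 is a step that the two limits leave unreadable from compound 1 to compound 2. The two readable steps both end at compound 3: an at least 6.5-fold lower number from compound 1 to compound 3 (0.81 log units; beyond the scatter) and an at least 6.5-fold lower number from compound 2 to compound 3 (0.81 log units; beyond the scatter); each exchanges the amine on the thiocarbonyl carbon.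

Compound 4 `CC(C)N(C(=S)SCc1coc2cc(Cl)ccc2c1=O)C(C)C` keeps diisopropylamino and differs from compound 2 by chloro in place of methyl on an aromatic carbon. Going by the values given here, no measured step touches that aromatic carbon; all three concern the amine, and none bears directly on this change. The starting point is itself a limit. For compound 4 in this assay the expectation is a value near the limit, 30000 nM, within 8000 nM to 100000 nM. The step this estimate implies is expected to be a step that the limit leaves unreadable from compound 2 to compound 4, with a substantial chance that this assay again returns only a limit.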

Compound 4, half-maximal inhibitory concentration: > 25000 nM
Compound 4: no number, only a limit; the forecaster's own chance of this, stated with the estimate: 65%; the middle value lies beyond the limit too.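

For the compounds shown here, compound 2 and compound 4 both stop at a limit in this assay, not at a number, so no step between them can be read. The compounds shown leave open whether chloro in place of methyl on that aromatic carbon changes the value at all, with diisopropylamino or with morpholin-4-yl on the thiocarbonyl carbon.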